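Swapping Allyloxy for Pyridin-2-yl: Expected Half-Life

The compounds below may be only part of what the source reports. "The series", "measured", "known", "first", "only" and "open" are said of these compounds alone.

Measured compounds:
compound 1, `C=CCOc1cc(F)cc(C(=O)NNS(=O)(=O)c2ccccc2F)c1`: 0.217 h
compound 2, `Cc1cc(-n2nccn2)cc(C(=O)NNS(=O)(=O)c2ccccc2)c1F`: 1.02 h

In an ADME assay on microsomes from liver (Homo sapiens) for metabolic stability, read by HPLC, using NADPH, with a stated time of 60 min, tested at 1 uM, in the presence of a further agent that is not named here (on this read-out lower numbers stand for a shorter-lived compound and higher numbers for a longer-lived compound), compound 1 gives 0.217 h, the lowest of the two numbers at hand. Compound 2 gives 1.02 h, a higher number that lies beyond the usual scatter of this assay.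

Compound 3, `O=C(NNS(=O)(=O)c1ccccc1F)c1cc(F)cc(-c2ccccn2)c1`, differs from compound 1 in one place: pyridin-2-yl in place of allyloxy on an aromatic carbon. Among the compounds with values here, no measured pair shows this exact change, so the size of its step cannot be read off directly. The value of compound 2 at 1.02 h shows that a related compound can be longer-lived in this assay. A moderate upward step is therefore expected, though uncertainty is wide. The step from compound 1 to compound 3 is estimated at a 1.8-fold higher number from compound 1 to compound 3 (0.27 log units; within the scatter). Compound 3 is expected to give 0.4 h, with a likely range from 0.18 h to 0.9 h.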

Compound 3, half-life: 0.933 h
For compound 3 the middle estimate is 2.3-fold (0.37 log units) below the measured one; measured number outside the range, above it.
By their numbers in this assay, from the lowest: compound 1; then compounds 3 and 2 (each within the scatter of the next).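

On this aromatic carbon of the core of compound 1 , putting pyridin-2-yl in place of allyloxy gives a 4.3-fold higher number from compound 1 to compound 3 (0.63 log units; beyond the scatter) in this assay. Within the data shown here, this is the first single change in the set whose size can be read directly, and it shows that the half-life responds to what sits at this position. Here, an open chain with a double bond gives way to a six-membered aromatic ring with a longer-lived result, and no measurement at hand says what lies behind the rise.

As far as these compounds go, whether a plain phenyl ring, with carbon only, would give the same half-life at this carbon stays open. So does whether the rise needs an aromatic ring at all, or whether a simple amine or a saturated chain of similar size would serve equally well.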